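Chloro in Place of Fluoro, Repeated on a Second Core

A few compounds are considered here, and "the series" means these few. Any claim that something is new, unique, unknown or untested is made for them only; others in the source may bear on it.

Measured so far:
compound 1 `O=C(O)c1cn(C2CC2)c2c(F)c(N3CCNCC3)c(F)cc2c1=O`: 47 ug/mL
compound 2 `O=C(O)c1cn(C2CC2)c2c(Cl)c(N3CCNCC3)c(F)cc2c1=O`: 43 ug/mL
compound 3 `NC1CCCN(c2c(F)cc3c(=O)c(C(=O)O)cn(C4CC4)c3c2F)C1`: 53 ug/mL

All three values come from a functional assay on V79 cells (Cricetulus griseus) for cytotoxicity, read by colony formation; a higher number here means a weaker inhibitor, a lower number a stronger inhibitor. Compound 2 differs from compound 1 by chloro in place of fluoro on an aromatic carbon, and that swap gave a 1.1-fold lower number from compound 1 to compound 2 (0.04 log units; within the scatter). Compound 3 differs from compound 1 in the other direction: 3-aminopiperidin-1-yl in place of piperazin-1-yl on an aromatic carbon, a change of the side group that gave a 1.1-fold higher number from compound 1 to compound 3 (0.05 log units; within the scatter). The three numbers therefore sit close together in this assay, and no order among them can be read from them.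

Compound 4 `NC1CCCN(c2c(F)cc3c(=O)c(C(=O)O)cn(C4CC4)c3c2Cl)C1` is not yet measured. It differs from compound 3 by chloro in place of fluoro on an aromatic carbon. Within the data shown here, this is the same kind of change as the one from compound 1 to compound 2, though the surroundings are not identical: in compound 1 the carbon is ortho to a piperazin-1-yl group, whereas in compound 3 it is ortho to a 3-aminopiperidin-1-yl group.

Since the earlier swap produced a 1.1-fold lower number from compound 1 to compound 2 (0.04 log units; within the scatter), a step within the scatter, compound 4 is expected to show a 1.1-fold lower number from compound 3 to compound 4 (0.03 log units; within the scatter) in this assay. Compound 4 is accordingly estimated at 49 ug/mL, with a likely range from 25 ug/mL to 95 ug/mL.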

Compound 4, half-maximal inhibitory concentration: 24 ug/mL
For compound 4 the middle estimate is 2.0-fold (0.31 log units) above the measured one, and the stated range ends above it.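

In this assay, chloro in place of fluoro gave a 2.2-fold lower number from compound 3 to compound 4 (0.34 log units; beyond the scatter), while the same swap between the two piperazin-1-yl compounds stayed within the scatter, yet the two steps lie no further apart than repeated measurements would allow: the same change on two cores in this assay, a 1.1-fold lower number (0.04 log units; within the scatter) from compound 1 to compound 2 and a 2.2-fold lower number (0.34 log units; beyond the scatter) from compound 3 to compound 4, 2.0-fold (0.31 log units) apart, within the scatter of two such steps. The side-group change, 3-aminopiperidin-1-yl in place of piperazin-1-yl, gave a 1.8-fold lower number from compound 2 to compound 4 (0.25 log units; within the scatter), and it also agrees with its earlier counterpart as far as the scatter can tell: the same change on two cores in this assay, a 1.1-fold higher number (0.05 log units; within the scatter) from compound 1 to compound 3 and a 1.8-fold lower number (0.25 log units; within the scatter) from compound 2 to compound 4, 2.0-fold (0.31 log units) apart, within the scatter of two such steps. So nothing here shows that either change behaves differently from one core to the other, but with only two pairs this does not prove that the changes carry over unchanged, and the larger step to compound 4 cannot be assigned to the side group.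

The compounds shown leave open what a bromo or methoxy group would do on that aromatic carbon. They also leave open whether a simple amine such as dimethylamino, in place of either side group, would give the same picture.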